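The Same Swap, Tried on a Second Core

The compounds below may be only part of what the source reports. "The series", "measured", "known", "first", "only" and "open" are said of these compounds alone.

Compound 1, `Cc1ccc(-c2nc3ccc(N4CCN(C)CC4)cc3[nH]2)cc1C#Cc1cnc(NC2CC2)nc1`: 1 nM
Compound 2, `Cc1ccc(-c2nc3ccc(N4CCN(C)CC4)cc3[nH]2)cc1C#Cc1cnc2cccnn12`: 0.5 nM
Compound 3, `Cc1ccc(C(=O)Nc2ccc3c(c2)C(F)(F)C[C@H]3N2CCN(C)CC2)cc1C#Cc1cnc(NC2CC2)nc1`: 10.4 nM

Of the compounds shown here, three have been measured in a functional assay on K562 cells (Homo sapiens) for inhibition, read by MTT assay, with a stated time of 72 h; on this read-out lower numbers stand for stronger inhibition and higher numbers for weaker inhibition. Compound 3 gives the highest number of the three, with 10.4 nM, and its gap to compound 1 and to compound 2 lies beyond the usual scatter, so it is the weakest of the measured set on this read-out.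

Compound 4, `Cc1ccc(C(=O)Nc2ccc3c(c2)C(F)(F)C[C@H]3N2CCN(C)CC2)cc1C#Cc1cnc2cccnn12`, is compound 3 with one change: a group of 9 heavy atoms (6 carbon, 3 nitrogen; one five-membered aromatic ring with 2 hetero atoms, one six-membered aromatic ring with 2 hetero atoms) in place of a group of 10 heavy atoms (7 carbon, 3 nitrogen; one three-membered non-aromatic ring of carbon only, one six-membered aromatic ring with 2 hetero atoms), on a triple-bonded carbon. The same exchange has already been seen once, on a different core, as the step from compound 1 to compound 2, which gave a 2.0-fold lower number from compound 1 to compound 2 (0.30 log units; within the scatter). Among the measured compounds shown here, that single step is the only direct guide, and it stayed within the scatter, so it supports no real shift in either direction.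

Because compound 3 gives 10.4 nM, the number for compound 4 is expected to sit close to it, perhaps slightly lower, with the estimated step of a 2.1-fold lower number from compound 3 to compound 4 (0.32 log units; beyond the scatter). Compound 4 is estimated at 5 nM, within a range from 1.5 nM to 15 nM.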

Compound 4, half-maximal inhibitory concentration: 3.6 nM
The estimate for compound 4 lay 1.4-fold (0.14 log units) above the measured number; the range from low to high includes it.
By their numbers in this assay, from the lowest: compounds 2 and 1 (each within the scatter of the next); then compound 4; then compound 3.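

In this assay, among the compounds shown here, putting the new fused ring group on the triple-bonded carbon in place of 2-(cyclopropylamino)pyrimidin-5-yl gives a 2.9-fold lower number from compound 3 to compound 4 (0.46 log units; beyond the scatter), so on this second core the change moves the number by more than the usual scatter, which the single earlier step did not do. The exchange also holds up even though the group that enters has no hydrogen-bond donor and the group that leaves has one. Seen side by side, the two steps run in the same direction and agree in size, so this position responds to the change in much the same way on both cores: the same change on two cores in this assay, a 2.0-fold lower number (0.30 log units; within the scatter) from compound 1 to compound 2 and a 2.9-fold lower number (0.46 log units; beyond the scatter) from compound 3 to compound 4, 1.4-fold (0.16 log units) apart, within the scatter of two such steps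

From the compounds shown here alone, what remains open is which part of the exchange matters, since the ring system and the cyclopropylamino group change together; a 2-aminopyrimidin-5-yl group, with a plain amine and no cyclopropyl ring, or a simple phenyl ring on the triple-bonded carbon would help to separate the two. Two cores are also a small base for a rule, and a cell read-out of this kind cannot by itself say why the number moves.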